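Swapping a Thiophene for a Pyridine Ring

The source may report more compounds than this note shows. Statements on the series, on what has been measured and on what is new or still open speak of the compounds shown alone.

Compound 2 `Oc1cccc(-c2cc(-c3ccc(Cl)cc3)nc(-c3cccs3)c2)c1` gives 15.1% in an assay on isolated protein for inhibition of DNA topoisomerase 1 (Homo sapiens), with a stated time of 30 min, tested at 100 uM (a lower number here means a weaker effect, a higher number a stronger effect of the compound at the concentration tested), the second highest of the three numbers. Compound 1 `Oc1ccc(-c2cc(-c3cccc(Cl)c3)nc(-c3ccccn3)c2)cc1` gives 59.4%, and compound 3 `Oc1cccc(-c2cc(-c3cccc(Cl)c3)nc(-c3cccs3)c2)c1` gives 7.6%. Among the measured compounds shown here, the only single-point step, a number 7.5 percentage points lower from compound 2 to compound 3 (within the scatter), lies within the scatter. Compound 4 `Oc1cccc(-c2cc(-c3ccc(Cl)cc3)nc(-c3cccnc3)c2)c1` differs from compound 2 by pyridin-3-yl in place of thiophen-2-yl on an aromatic carbon. For the measured compounds named here, no measured step changes this group: compound 1 carries a different six-membered ring at this position, but it also differs in two other places, so its number cannot be attributed to the ring alone. Without a guiding step, the change is expected to be small: a number 9.9 percentage points higher from compound 2 to compound 4 (within the scatter). The estimated value for compound 4 is 25%, with a range from 5% to 55%.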

Compound 4, a percentage reported as inhibition, at one concentration (the size of the read-out at that concentration, not a potency): 2.8%
The estimate for compound 4 lay 22.2 percentage points above the measured number; measured number outside the range, below it.
By their numbers in this assay, from the lowest: compounds 4, 3 and 2 (each within the scatter of the next, the first and the last beyond it); then compound 1.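

Among the compounds shown here, this is the first readable step at the position next to the ring nitrogen: pyridin-3-yl in place of thiophen-2-yl gives a number 12.3 percentage points lower from compound 2 to compound 4 (beyond the scatter). The position therefore responds to a change of ring, and here a six-membered ring with one nitrogen does not raise the number. Nothing given here explains the step.

Still open, as far as these compounds go, is how pyridin-2-yl would behave on the otherwise unchanged core of compound 2. Equally open, from the compounds shown here alone, is whether a non-aromatic group at this position, such as an amine or a carboxylic acid, would restore or further lower the number.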